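The source may hold more compounds than are shown below. What is called first, only, known or untested is meant among the compounds shown, and "the series" means these compounds.

Compound 3 `Cc1nc2c(OCc3ccccc3)cccn2c1/N=C/N(C)C` was tested in a functional assay on the whole organism with Canis familiaris (Canis lupus familiaris) as the target, at a dose of 2 mg/kg by the intravenous route (on this read-out higher numbers stand for a stronger effect at the one dose given and lower numbers for a weaker effect), where compound 3 gives 12%. That places compound 3 second of three: compound 2 `Cc1nc2c(OCc3ccccc3)cccn2c1NC=O` gives 3%, within the scatter of it, while compound 1 `Cc1nc2c(OCc3ccccc3)cccn2c1N` gives 97%, far above. Compound 4 `CCCNc1c(C)nc2c(OCc3ccccc3)cccn12` is not yet measured; its change from compound 3 is a group of 4 heavy atoms (3 carbon, 1 nitrogen; no ring) in place of a group of 5 heavy atoms (3 carbon, 2 nitrogen; no ring), on an aromatic carbon. For the measured compounds named here, two measured steps bear on this. Going from the plain amine cost a number 85 percentage points lower from compound 1 to compound 3 (beyond the scatter), whereas a number 9 percentage points higher from compound 2 to compound 3 (within the scatter) changed nothing beyond the scatter. The propylamino group that enters resembles the amine of compound 1 more than the group it replaces, so a large rise is expected, though not the full recovery. Compound 4 is expected to give 60%, within 25% to 90%. The expected step is a number 48 percentage points higher from compound 3 to compound 4 (beyond the scatter).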

Compound 4, a percentage reported as inhibition, in the whole organism at one dose (the size of the read-out at that dose, not a potency): 12%
Compound 4: the middle estimate sits 48 percentage points above what was measured; the measured number lies below the stated range.
By their numbers in this assay, from the lowest: compounds 2, 3 and 4 (each within the scatter of the next); then compound 1.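

In this assay, putting propyl on the nitrogen of the plain amine brings a number 85 percentage points lower from compound 1 to compound 4 (beyond the scatter) as a large loss, so a simple alkyl chain on this nitrogen does not preserve the effect. Propylamino has a hydrogen-bond donor that the leaving group lacks, yet the result is no change at the digits printed from compound 3 to compound 4 (within the scatter) and, with propyl in place of formyl, a number 9 percentage points higher from compound 2 to compound 4 (within the scatter) as well. All three substituted nitrogens shown therefore sit far from the plain amine, with no exception among these compounds.

From the compounds shown here alone, whether a methyl or ethyl on this nitrogen would fare better remains open. What lies behind the loss also stays open, as no supporting data bear on it.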